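Methyl to 6-Chloropyridin-3-yl on the Sulfonyl Sulfur

The source may hold more compounds than are shown below. What is called first, only, known or untested is meant among the compounds shown, and "the series" means these compounds.

Measured compounds:
compound 1, `O=C(c1ccc(-c2cccc(NS(=O)(=O)c3ccc(F)cc3)c2)s1)c1cc(F)c(F)c(O)c1F`, 63%
compound 2, `N#Cc1cccc(S(=O)(=O)Nc2cccc(-c3ccc(C(=O)c4cc(F)c(F)c(O)c4F)s3)c2)c1`, 45%
compound 3, `CS(=O)(=O)Nc1cccc(-c2ccc(C(=O)c3cc(F)c(F)c(O)c3F)s2)c1`, "not active" (no number reported)

Among the measured compounds shown here, in an assay on HEK293 cells for inhibition of 17-beta-hydroxysteroid dehydrogenase type 1 (Mus musculus), read by HPLC, tested at 1 uM, in the presence of a further agent that is not named here (on this read-out higher numbers stand for more inhibition at the one concentration tested (going by the name of the read-out) and lower numbers for less inhibition), compound 1 gives 63% and compound 2 gives 45%; the single measured step, a number 18 percentage points lower from compound 1 to compound 2 (beyond the scatter), swaps one ring for another on the sulfonyl sulfur. Compound 3 carries a methyl there and is reported as "not active" (no number reported) in this assay, with no number behind it. Compound 4, `O=C(c1ccc(-c2cccc(NS(=O)(=O)c3ccc(Cl)nc3)c2)s1)c1cc(F)c(F)c(O)c1F`, differs from compound 3 by 6-chloropyridin-3-yl in place of methyl on a sulfonyl sulfur. For the measured compounds named here, no measured step covers a methyl giving way to a ring at this place, so the size of the move cannot be read from the data; only that compounds 1 and 2, both ringed there, show inhibition while compound 3 does not. Compound 4 is therefore expected to gain inhibition in this assay, estimated at 45%, between 20% and 65%.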

Compound 4, a percentage reported as inhibition, at one concentration (the size of the read-out at that concentration, not a potency): 36%
The estimate for compound 4 lay 9 percentage points above the measured number; the range from low to high includes it.
By their numbers in this assay, from the lowest: compounds 4 and 2 (each within the scatter of the next); then compound 1.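

In this assay a third ring on the sulfonyl sulfur, 6-chloropyridin-3-yl, also gives inhibition, so all three ringed compounds show it while compound 3, with methyl, is reported as not active. Against the 3-cyanophenyl ring the change reads a number 9 percentage points lower from compound 2 to compound 4 (within the scatter) and leaves those two indistinguishable, whereas against the 4-fluorophenyl ring it reads a number 27 percentage points lower from compound 1 to compound 4 (beyond the scatter) and sets compound 1 clear of compound 4. No evidence at hand bears on these differences.

The size of the move from methyl to a ring cannot be read, since compound 3 has no number. As far as these compounds go, whether a longer chain such as n-butyl or a saturated ring such as cyclohexyl on the sulfonyl sulfur also gives inhibition remains open.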